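Swapping Oxygen for Sulfur in a Small Ring

The source may hold more compounds than are shown below. What is called first, only, known or untested is meant among the compounds shown, and "the series" means these compounds.

Two compounds have been examined in a functional assay, read by Griess assay, with a stated time of 150 min, tested at 50 ug/mL; a lower number here means a weaker effect, a higher number a stronger effect of the compound at the concentration tested. Compound 1 `O=S(=O)(CC1=NCCO1)c1c(-c2ccccc2)nn(-c2ccccc2)c1-c1ccccc1` gives 54.5% in this assay. Compound 2 `O=S(=O)(CC1=NCCO1)C1C(c2ccccc2)=NOC1c1ccccc1` gives 53.9% in this assay. For the measured compounds named here, the two values sit within the usual scatter of each other, so nothing separates compound 1 from compound 2 on these numbers, and compound 2 can only be said to stand at the same level as its one neighbour.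

The next compound, compound 3 `O=S(=O)(CC1=NCCS1)C1C(c2ccccc2)=NOC1c1ccccc1`, differs from compound 2 in a single place: a group of 5 heavy atoms (3 carbon, 1 nitrogen, 1 sulfur; one five-membered non-aromatic ring with 2 hetero atoms) in place of a group of 5 heavy atoms (3 carbon, 1 nitrogen, 1 oxygen; one five-membered non-aromatic ring with 2 hetero atoms), on a saturated chain carbon bound to a sulfonyl sulfur. The rest of the shared core is untouched.

Going by the values given here, no measured pair shows what such an exchange of one ring for the other does in this assay, so there is no step to lean on. The change is small in size and keeps the ring count and the acceptor count the same, which gives no ground to expect a large move in either direction. The expected step from compound 2 to compound 3 is therefore a number 1.1 percentage points higher from compound 2 to compound 3 (within the scatter), none beyond the scatter. Compound 3 is estimated at 55%, with a range from 35% to 75%.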

Compound 3, a percentage reported as activity, at one concentration (the size of the read-out at that concentration, not a potency): "not active" (no number reported)
Compound 3: no number reported, so the estimate cannot be set against anything.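

In this assay, for the compounds shown here, compound 3 is reported as not active, without a number, so no step from compound 2 to compound 3 can be read. Nothing available bears on this result. The compounds shown leave open how far the exchange of oxygen for sulfur in this five-membered ring moves the read-out.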